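Amino for Dimethylamino on the Shared Core

A few compounds are considered here, and "the series" means these few. Any claim that something is new, unique, unknown or untested is made for them only; others in the source may bear on it.

The series is followed in a functional assay on the whole organism (Pleural cavity) with Rattus norvegicus as the target; a higher number here means that more compound is needed for the effect, a lower number that less compound is needed. Compound 1, `OC[C@H]1OC(n2cnc3c(SCc4ccccc4)nccc32)[C@H](O)[C@@H]1O`, gives 9 mg/kg in this assay. Compound 2, `OC[C@H]1O[C@@H](n2cnc3c(NCc4ccccc4)nccc32)C[C@@H]1O`, is reported in this assay only as a limit of > 9 mg/kg, not as a number. Compound 3, `CN(C)c1[nH]ccc2ncnc1-2`, gives 9 mg/kg in this assay, so compound 3 stands level with compound 1 at the digits shown, and the values of compound 1 and compound 3 lie within the scatter of each other. Of the three results, one is a limit: the limit of > 9 mg/kg in this assay, at which 1 of the 3 values shown sits.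

The next compound is compound 4, `Nc1[nH]ccc2ncnc1-2`, which differs from compound 3 in one place: amino in place of dimethylamino on an aromatic carbon. Among the compounds with values here, no measured pair in this set shows the same change, so there is no step from which to read its size. With only the value of compound 3 at 9 mg/kg as an anchor, the expectation is a step of no change at the digits printed from compound 3 to compound 4 (within the scatter), that is, no change beyond the scatter in either direction. Compound 4 is therefore estimated at 9 mg/kg in this assay, with a range from 3 mg/kg to 30 mg/kg.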

Compound 4, dose for half-maximal effect: 8 mg/kg
Estimate against measurement, compound 4: 1.1-fold (0.05 log units) above; the range from low to high includes it.
By their numbers in this assay, from the lowest: compounds 4, 1 and 3 (each within the scatter of the next).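

In this assay, the exchange of dimethylamino for amino gives a 1.1-fold lower number from compound 3 to compound 4 (0.05 log units; within the scatter). Within the data shown here, the earlier compounds held no pair that differed in one place, so this is the first step that can be read at all, and it gives the first direct view of this position, on an aromatic carbon next to the ring nitrogen. Here amino brings a hydrogen-bond donor that dimethylamino does not have, and it carries fewer heavy atoms, yet the two compounds read level, so on this small core neither difference moves the number beyond the scatter.

From the compounds shown here alone, whether the position stays as undemanding for other groups remains open, whether for methylamino, for a longer chain on the nitrogen such as diethylamino, or for a carboxylic acid on the same carbon, and whether the same exchange would read alike on a core carrying the larger substituents of compound 1 is equally unsettled. Nothing in the values shown bears on why amino and dimethylamino read alike here.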